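The source may hold more compounds than are shown below. What is called first, only, known or untested is meant among the compounds shown, and "the series" means these compounds.

Measured compounds:
compound 1 `O[C@@H]1CO[C@@H](Oc2ccc3ccccc3c2)C[C@H]1O`, 228 uM;
compound 2 `CO[C@H]1[C@H](Oc2ccc3ccccc3c2)OC[C@@H](O)[C@@H]1O`, 127 uM;
compound 3 `O[C@H]1[C@H](Oc2ccc3ccccc3c2)OCC[C@@H]1O`, 284 uM.

All three were tested in a functional assay on HCC70 cells (Homo sapiens) for antiproliferative activity, read by crystal violet staining, with a stated time of 96 h; on this read-out lower numbers stand for an effect already at smaller amounts and higher numbers for an effect only at larger amounts of compound. Compound 2 differs from compound 1 by methoxy in place of hydrogen on a saturated ring carbon, and this change gave a 1.8-fold lower number from compound 1 to compound 2 (0.25 log units; within the scatter). Compound 4 `CO[C@@H]1CO[C@@H](Oc2ccc3ccccc3c2)[C@H](O)[C@H]1O` differs from compound 3 by methoxy in place of hydrogen on a saturated ring carbon, the same kind of change, but the place differs: in the step from compound 1 to compound 2 the methoxy enters next to the ring atom that bears a large group, whereas in compound 4 it sits three ring bonds from the ring atom that bears a large group. The cores of compounds 1 and 3 have the same atoms joined differently; that difference is not broken down here. For the measured compounds named here, because the only precedent is a 1.8-fold lower number from compound 1 to compound 2 (0.25 log units; within the scatter), compound 4 is expected to show a step of a 1.7-fold lower number from compound 3 to compound 4 (0.22 log units; within the scatter). The estimate for compound 4 is 170 uM, ranging from 80 uM to 360 uM.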

Compound 4, concentration for half-maximal effect: 135 uM
Compound 4: middle estimate off by 1.3-fold (0.10 log units), on the high side; the range from low to high includes it.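

In this assay, methoxy in place of hydrogen on a saturated ring carbon gave a 2.1-fold lower number from compound 3 to compound 4 (0.32 log units; beyond the scatter), and this step can be set beside the earlier one: the same change on two cores in this assay, a 1.8-fold lower number (0.25 log units; within the scatter) from compound 1 to compound 2 and a 2.1-fold lower number (0.32 log units; beyond the scatter) from compound 3 to compound 4, 1.2-fold (0.07 log units) apart, within the scatter of two such steps. The change therefore carried between these two cores with a step of similar size, although the methoxy sits in a different place on each. This does not show that it would carry to any further core, and two steps cannot separate the contribution of the place from that of the core.

The compounds shown leave open whether an amine, a carboxylic acid or a longer chain in place of the methoxy would give a similar step. As far as these compounds go, whether the step holds in other cell lines also remains open.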